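Cyanoacrylamide series: furan-to-tolyl change, compound 3 pending

A few compounds are considered here, and "the series" means these few. Any claim that something is new, unique, unknown or untested is made for them only; others in the source may bear on it.

Measured so far:
compound 1, `N#C/C(=C\c1ccc[nH]1)C(=O)NCc1ccc(Cl)c(Cl)c1`: 43000 nM
compound 2, `COc1ccc(CNC(=O)/C(C#N)=C/c2ccco2)cc1`: 24000 nM

Both numbers come from a functional assay on BE(2)-C cells (Homo sapiens) for inhibition, read by MTT assay, with a stated time of 72 h; a lower number here means a stronger inhibitor of growth, a higher number a weaker inhibitor of growth. Compound 2 holds the lower of the two numbers; the gap to compound 1 falls within the usual scatter, so neither compound can be called the stronger on this evidence. The two compounds differ in more than one place, so no single step can be read from them.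

Compound 3, `COc1ccc(CNC(=O)/C(C#N)=C/c2ccc(C)cc2)cc1`, is not yet measured. It differs from compound 2 by 4-methylphenyl in place of furan-2-yl on a double-bonded chain carbon bound to a double-bonded chain carbon. Among the compounds with values here, no measured pair shows this change in this assay, so the size of the step rests on expectation alone. Because compound 1 at 43000 nM and compound 2 at 24000 nM sit within the scatter of each other despite differing in more than one place, a change confined to one ring is expected to move the number little. The expected step is a 1.3-fold higher number from compound 2 to compound 3 (0.10 log units; within the scatter), nothing beyond the scatter. For compound 3 in this assay the estimate is 30000 nM, with a range from 8000 nM to 120000 nM.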

Compound 3, concentration for 50% growth inhibition: 35000 nM
The estimate for compound 3 lay 1.2-fold (0.07 log units) below the measured number; the measured number falls inside the stated range.
By their numbers in this assay, from the lowest: compounds 2, 3 and 1 (each within the scatter of the next).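

In this assay, within the data shown here, the series now has its only single-place step: 4-methylphenyl in place of furan-2-yl on a double-bonded chain carbon bound to a double-bonded chain carbon gives a 1.5-fold higher number from compound 2 to compound 3 (0.16 log units; within the scatter). At this position, then, a six-membered aromatic ring of carbon only and a five-membered aromatic ring with 1 hetero atom are not told apart by this read-out, even though the entering group has 7 heavy atoms against 5 and no hydrogen-bond acceptor against 1. No measurement on any property of these groups accompanies the step, and the tolerance seen here stands without an explanation.

Whether a dimethylamino group or a carboxylic acid on the aromatic ring at this position would give a step beyond the scatter remains open, since both groups shown here are uncharged aromatic rings and a single pair cannot define the limits of the position. Among these compounds, also open is what a longer chain on the amide nitrogen would do, as compound 1 differs from compound 2 and compound 3 in more than one place and gives no step on that side of the shared core.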